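This account rests on a few compounds, and the source may have more. Where it says the series, first, only, none or still open, it means among the compounds named here.

Of the compounds shown here, three sharing one core have so far been tested in a functional assay on HCC1806 cells (Homo sapiens) for inhibition, read by sulforhodamine B assay, tested at 10 uM; a higher number here means more inhibition at the concentration tested (going by the name of the read-out), a lower number less inhibition. Compound 1, `CN(C)c1ccc(C2CC(c3ccc(-n4cncn4)cc3)=NN2)cc1`, gives 6.8%. Compound 2, `CC(=O)N1N=C(c2ccc(-n3cncn3)cc2)CC1c1ccc(N(C)C)cc1`, differs by an acetyl in place of hydrogen on an amine nitrogen in a ring and gives 11%; the step of a number 4.2 percentage points higher from compound 1 to compound 2 (within the scatter) lies within the scatter. Compound 3, `CN(C)c1ccc(C2CC(c3ccc(-n4cncn4)cc3)=NN2C(=O)CCCl)cc1`, carries a (2-chloroethyl)carbonyl on that nitrogen and gives -3.4%, the lowest of the three numbers, with a number 10.2 percentage points lower from compound 1 to compound 3 (beyond the scatter) and a number 14.4 percentage points lower from compound 2 to compound 3 (beyond the scatter) both modest but beyond the scatter.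

Compound 4, `COC(=O)CC(=O)N1N=C(c2ccc(-n3cncn3)cc2)CC1c1ccc(N(C)C)cc1`, differs from compound 3 by methoxycarbonyl in place of chloromethyl on a saturated chain carbon bound to a carbonyl carbon. The step that bears most directly on this change is a number 14.4 percentage points lower from compound 2 to compound 3 (beyond the scatter), which shows that adding a group at this saturated chain carbon lowered the number modestly; a number 10.2 percentage points lower from compound 1 to compound 3 (beyond the scatter) points the same way. Since all three measured numbers sit in a low band, it is expected that exchanging one small group for another at this carbon will move compound 4 only a little, with a number 8.4 percentage points higher from compound 3 to compound 4 (within the scatter) most likely within the scatter. The estimate for compound 4 in this assay is therefore 5%, with a range from -8% to 18%.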

Compound 4, a percentage reported as inhibition, at one concentration (the size of the read-out at that concentration, not a potency): -7.8%
Compound 4: the middle estimate sits 12.8 percentage points above what was measured, within the range that was stated.
By their numbers in this assay, from the lowest: compounds 4 and 3 (each within the scatter of the next); then compounds 1 and 2 (each within the scatter of the next).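

In this assay, methoxycarbonyl in place of chloromethyl on a saturated chain carbon bound to a carbonyl carbon gives a number 4.4 percentage points lower from compound 3 to compound 4 (within the scatter), so the two groups cannot be told apart here, even though they differ in size and methoxycarbonyl brings hydrogen-bond acceptors that chloromethyl lacks. The same group in place of hydrogen on that carbon gives a number 18.8 percentage points lower from compound 2 to compound 4 (beyond the scatter), and the whole ((methoxycarbonyl)methyl)carbonyl group in place of hydrogen on the ring nitrogen gives a number 14.6 percentage points lower from compound 1 to compound 4 (beyond the scatter), so two different groups on this carbon now stand apart from hydrogen in the same direction. Nothing at hand explains this result. From the compounds shown here alone, whether an amine, a carboxylic acid or a longer chain on this carbon would follow the same direction remains open. Also open, going by these compounds, is whether any acyl group on the ring nitrogen would raise the number beyond the scatter of compound 1.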